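Small sulfated sugar amides and vascular endothelial growth factor binding

The source may hold more compounds than are shown below. What is called first, only, known or untested is meant among the compounds shown, and "the series" means these compounds.

This account concerns two measured compounds and one still untested. Compound 1 `CO[C@H]1O[C@H](CNC(=O)CN(C(C)=O)C2CCCCCC2)[C@@H](OS(=O)(=O)O)[C@H](OS(=O)(=O)O)[C@@H]1OS(=O)(=O)O` and compound 2 `CCN(CC(=O)NCCO[C@H]1O[C@H](COS(=O)(=O)O)[C@@H](OS(=O)(=O)O)[C@H](OS(=O)(=O)O)[C@@H]1OS(=O)(=O)O)C(=O)CCCCCCCCCOS(=O)(=O)O` were both examined in an assay on isolated protein for binding affinity to vascular endothelial growth factor A, long form (Homo sapiens), read by surface plasmon resonance; a higher number here means weaker binding, a lower number tighter binding. In this assay compound 1 gives 3000000 nM, the highest of the two numbers, while compound 2 gives 50000 nM, a gap the two values show directly. Compound 3 `CCN(CC(=O)NC[C@H]1O[C@H](OC)[C@@H](OS(=O)(=O)O)[C@@H](OS(=O)(=O)O)[C@@H]1OS(=O)(=O)O)C(=O)CCCCC(=O)O` is the compound yet to be measured. It differs from compound 1 in one place: ((4-carboxybutyl)carbonyl)(ethyl)amino in place of acetyl(cycloheptyl)amino on a saturated chain carbon bound to a carbonyl carbon. For the measured compounds named here, no step between measured compounds that differ in a single place is available, so this change has no measured precedent here. Compound 3 is expected to bind somewhat more tightly than compound 1, with a step of a 3.0-fold lower number from compound 1 to compound 3 (0.48 log units; beyond the scatter) of modest size, though a step within the scatter cannot be excluded. For compound 3 the expected value in this assay is 1000000 nM, with a range from 300000 nM to 3000000 nM.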

Compound 3, dissociation constant: 104000 nM
Compound 3: middle estimate off by 9.6-fold (0.98 log units), on the high side, and the stated range ends above it.
By their numbers in this assay, from the lowest: compound 2; then compound 3; then compound 1.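

At this position, on a saturated chain carbon bound to a carbonyl carbon, this assay gives a 29-fold lower number from compound 1 to compound 3 (1.46 log units; beyond the scatter) when ((4-carboxybutyl)carbonyl)(ethyl)amino replaces acetyl(cycloheptyl)amino. For the compounds shown here, this is the first measured reading at this place, and it shows that the read-out responds strongly to the group standing there and that the seven-membered ring is not required for the tighter value. Nothing measured here explains the size of this step.

The exchange alters the whole group at once, so the compounds shown do not separate the part played by the ethyl from that of the 4-carboxybutyl chain. As far as these compounds go, whether the carboxylic acid at the chain end matters remains open, and an amine or a plain methyl at that chain end, or a longer chain, would bear on this.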